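From Methoxycarbonyl to Ethylcarbamoyl: Compound 4 Expected

This account rests on a few compounds, and the source may have more. Where it says the series, first, only, none or still open, it means among the compounds named here.

The measured compounds so far:
- Compound 1 `COc1ccc2nc(-c3n[nH]cc3/C=C/c3cccnc3)[nH]c2c1`: 1800 nM
- Compound 2 `COc1cncc(/C=C/c2c[nH]nc2-c2nc3ccc(OC)cc3[nH]2)c1`: 890 nM
- Compound 3 `COC(=O)c1cncc(/C=C/c2c[nH]nc2-c2nc3ccc(OC)cc3[nH]2)c1`: 4400 nM

In a functional assay on HeLa cells (Homo sapiens) for antiproliferative activity (on this read-out higher numbers stand for weaker inhibition and lower numbers for stronger inhibition), compound 3 gives the highest of the three numbers. Its nearest neighbour is compound 1, reached by a 2.4-fold higher number from compound 1 to compound 3 (0.39 log units; beyond the scatter); the furthest is compound 2, reached by a 4.9-fold higher number from compound 2 to compound 3 (0.69 log units; beyond the scatter). The first of these replaces hydrogen with methoxycarbonyl, the second replaces methoxy with methoxycarbonyl, both on the same aromatic carbon, and both make the number worse.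

Compound 4 `CCNC(=O)c1cncc(/C=C/c2c[nH]nc2-c2nc3ccc(OC)cc3[nH]2)c1` differs from compound 3 by ethylamino in place of methoxy on a carbonyl carbon. For the measured compounds named here, no measured step changes the group attached to that carbonyl carbon, so the two steps above bear on it only indirectly: they show that what sits on this aromatic carbon matters, but they do not say whether exchanging methoxy for ethylamino moves the number up or down. With nothing to point one way, the expected step in this assay is a 1.3-fold lower number from compound 3 to compound 4 (0.10 log units; within the scatter), that is, none beyond the scatter, with a wide range in either direction.

The estimate for compound 4 in this assay is therefore 3500 nM, between 1200 nM and 10000 nM.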

Compound 4, half-maximal inhibitory concentration: 3700 nM
For compound 4 the middle estimate is 1.1-fold (0.02 log units) below the measured one, and the stated range covers the measured number.
By their numbers in this assay, from the lowest: compound 2; then compound 1; then compounds 4 and 3 (each within the scatter of the next).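

In this assay, the first change shown at the carbonyl carbon itself gives a 1.2-fold lower number from compound 3 to compound 4 (0.08 log units; within the scatter) so methoxycarbonyl and ethylcarbamoyl cannot be told apart here, even though ethylamino brings a hydrogen-bond donor that methoxy lacks. Ethylcarbamoyl on the aromatic carbon also repeats the standing of methoxycarbonyl against the other two groups there: a 2.1-fold higher number from compound 1 to compound 4 (0.31 log units; beyond the scatter) and a 4.2-fold higher number from compound 2 to compound 4 (0.62 log units; beyond the scatter) place it on the weaker side of both hydrogen and methoxy, and none of the four compounds goes against this pattern. Nothing shown here accounts for the two carbonyl groups reading alike.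

On these data alone, it remains open whether the insensitivity at the carbonyl carbon extends beyond methoxy and ethylamino, for instance to a carboxylic acid, an unsubstituted carboxamide or a longer chain in place of ethyl. As far as these compounds go, it is equally open whether a group without a carbonyl on the aromatic carbon, such as an amine or an ethoxy group, would read closer to methoxy than the two carbonyl groups do.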